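A Dimethylmorpholine Amide in Place of a Piperidine Amide

The source may report more compounds than this note shows. Statements on the series, on what has been measured and on what is new or still open speak of the compounds shown alone.

Compound 3 `Cn1c(/C=C2\SC(=O)N(CC(=O)N3CCCCC3)C2=O)nc2ccccc21` carries a piperidin-1-yl group on the carbonyl carbon of the side chain. In a functional assay on A549 cells (Homo sapiens) for inhibition, read by MTT assay, with a stated time of 48 h (a lower number here means a stronger inhibitor, a higher number a weaker inhibitor), compound 3 gives > 50000 nM, which is a limit of the assay and not a number. Its nearest measured neighbour is compound 2 `Cn1c(/C=C2\SC(=O)N(CC(=O)N3CCOCC3)C2=O)nc2ccccc21`, which bears morpholin-4-yl at the same place. In this assay compound 2 gives 38500 nM. The step of an at least 1.2-fold higher number from compound 2 to compound 3 (0.11 log units; that floor lies within the scatter) is thus only a floor that tells little about the true size of the difference. Compound 1 `CCn1c(/C=C2\SC(=O)N(CC(=O)N3CCCCC3)C2=O)nc2ccccc21` differs from compound 3 only by an ethyl group on the aromatic nitrogen. In this assay compound 1 gives > 50000 nM, again a limit. The step that the two limits leave unreadable from compound 1 to compound 3 cannot be read because both values rest at the limit of > 50000 nM in this assay, at which 2 of the 3 values shown sit.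

The unmeasured compound 4 `CC1CN(C(=O)CN2C(=O)S/C(=C\c3nc4ccccc4n3C)C2=O)CC(C)O1` carries the change (2,6-dimethylmorpholin-4-yl in place of piperidin-1-yl on a carbonyl carbon). For the measured compounds named here, this runs in the direction opposite to the step from compound 2 to compound 3, so a move toward a readable number, of modest size, is expected; the two added methyl groups have no measured counterpart here, so no further shift is assumed. Compound 4 is expected to give 42000 nM in this assay, somewhere between 18000 nM and 90000 nM, with a real chance of another limit. The expected step of an at least 1.1-fold lower number from compound 3 to compound 4 (0.07 log units; that floor lies within the scatter) is an estimate that the result will sit near that of compound 2.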

Compound 4, half-maximal inhibitory concentration: 29400 nM
Compound 4: middle estimate off by 1.4-fold (0.15 log units), on the high side, within the range that was stated.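

Placing 2,6-dimethylmorpholin-4-yl on this carbonyl carbon in place of piperidin-1-yl gives a readable value in this assay, yet the step is only a floor, an at least 1.7-fold lower number from compound 3 to compound 4 (0.23 log units; that floor lies within the scatter), and compound 3 rests at a limit of the assay: the limit of > 50000 nM in this assay, at which 2 of the 4 values shown sit.

The new compound also shows that the two methyl groups make no readable difference at this position, since the step is a 1.3-fold lower number from compound 2 to compound 4 (0.12 log units; within the scatter). Among the four compounds shown, the two that carry a morpholine-type amide, compound 2 and compound 4, give readable values, while the two that carry piperidin-1-yl, compound 1 and compound 3, do not, and no compound shown goes against this.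

The compounds shown leave open whether a piperazin-1-yl or a pyrrolidin-1-yl group on this carbonyl carbon would behave like morpholin-4-yl or like piperidin-1-yl. They also leave open how an ethyl group on the aromatic nitrogen would act in the presence of 2,6-dimethylmorpholin-4-yl, and how far compound 3 truly lies from compound 4.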